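Phenyl Ketone in Place of an Allyl Ester

The source may hold more compounds than are shown below. What is called first, only, known or untested is meant among the compounds shown, and "the series" means these compounds.

Within the data shown here, compound 1 `C=CCOC(=O)/C=C(C)/C=C/CC(C)CCCC(C)C` is one of two compounds measured in a physicochemical assay for lipophilicity; on this read-out lower numbers stand for lower lipophilicity and higher numbers for higher lipophilicity. In this assay compound 1 gives 6.73, the higher of the two numbers recorded. Among the measured compounds shown here, compound 2 `CCNC(=O)OC(C)(C)CCCC(C)C/C=C/C(C)=C/C(=O)OC(C)C` gives 6.06 in this assay, a lower reading, though no single structural step separates it from compound 1, so only the two numbers themselves can be compared.

Compound 3 `CC(/C=C/CC(C)CCCC(C)C)=C\C(=O)c1ccccc1` has not yet been measured. Compared with compound 1 it shows one difference: phenyl in place of allyloxy on a carbonyl carbon. For the measured compounds named here, no pair of measured compounds in this set differs in exactly this way, so there is no directly comparable step to lean on. Given that compound 1 already gives 6.73 in this assay, compound 3 is expected to move a little higher, a step of about a number 0.37 log units higher from compound 1 to compound 3 (beyond the scatter). Compound 3 is therefore estimated at 7.1 in this assay, within a range from 6.6 to 7.7.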

Compound 3, partition coefficient: 7.26
The estimate for compound 3 lay 0.16 log units below the measured number, within the range that was stated.
By their numbers in this assay, from the lowest: compound 2; then compound 1; then compound 3.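

Among these compounds, on the carbonyl carbon of the core of compound 1, this is the first change whose effect can be read directly. Among the compounds shown here, all earlier comparisons rested on two compounds with no single structural step between them. In this assay, phenyl in place of allyloxy gives a number 0.53 log units higher from compound 1 to compound 3 (beyond the scatter) and so shows that this position responds to the group it carries. The swap replaces a group with a hydrogen-bond acceptor and a double bond with a six-membered aromatic ring of carbon only, and this one step cannot separate those differences, while nothing in the data bears on the cause of the step.

From the compounds shown here alone, it remains open how other groups on this carbonyl carbon, such as an amine or a longer chain, would compare with phenyl and allyloxy. Going by these compounds, whether the same change would give a step of similar size on the core of compound 2 is also open.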